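Swapping a Ring-Bearing Group for an Open Chain

The source may report more compounds than this note shows. Statements on the series, on what has been measured and on what is new or still open speak of the compounds shown alone.

Of the compounds shown here, three sharing one core have been tested in a functional assay on HepG2 cells (Homo sapiens) for inhibition, read by MTT assay, with a stated time of 48 h; a higher number here means a weaker inhibitor, a lower number a stronger inhibitor. Compound 1 `CCOC(=O)C1=C(NN=C(C(C)=O)C(C)=O)Nc2[nH]nc(C)c2C1c1ccc(N(C)C)cc1` gives 8480 nM. Compound 2 `CCOC(=O)C1=C(N/C=N/c2nnc(S(N)(=O)=O)s2)Nc2[nH]nc(C)c2C1c1ccc(N(C)C)cc1` gives 38100 nM, the highest of the three numbers, and compound 3 `CCOC(=O)C1=C(N/C=N/c2ccccn2)Nc2[nH]nc(C)c2C1c1ccc(N(C)C)cc1` gives 26200 nM. Compound 2 is nearest to compound 3, as a 1.5-fold lower number from compound 2 to compound 3 (0.16 log units; within the scatter) shows, and furthest from compound 1, as a 4.5-fold higher number from compound 1 to compound 2 (0.65 log units; beyond the scatter) shows.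

Compound 4 `CCOC(=O)C1=C(N/N=C(/C(C)=O)C(=O)OCC)Nc2[nH]nc(C)c2C1c1ccc(N(C)C)cc1` has not yet been measured in this assay. It differs from compound 2 in one place: a group of 10 heavy atoms (6 carbon, 1 nitrogen, 3 oxygen; no ring) in place of a group of 11 heavy atoms (3 carbon, 4 nitrogen, 2 oxygen, 2 sulfur; one five-membered aromatic ring with 3 hetero atoms), on an amine nitrogen. Within the data shown here, the group that enters is an open chain, much like the one carried by compound 1 on the same amine nitrogen, whereas compound 2 and compound 3 carry ring-bearing groups there.

Among the measured compounds shown here, the steps that bear on this change are a 4.5-fold higher number from compound 1 to compound 2 (0.65 log units; beyond the scatter) and a 3.1-fold higher number from compound 1 to compound 3 (0.49 log units; beyond the scatter), both modest rises in the number when a ring-bearing group replaced the open chain of compound 1. Reversing that kind of change in compound 4 is therefore expected to give a lower number, estimated as a 3.8-fold lower number from compound 2 to compound 4 (0.58 log units; beyond the scatter). Compound 4 is expected to come out near compound 1, at an estimated 10000 nM, with a likely range from 4000 nM to 25000 nM.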

Compound 4, half-maximal inhibitory concentration: > 100000 nM
Compound 4: no number, only a limit; the forecaster's own chance of this, stated with the estimate: 5%; middle value at least 10-fold (1.00 log units) away from the limit.
By their numbers in this assay, from the lowest: compound 1; then compounds 3 and 2 (each within the scatter of the next). At a limit, above all of these: compound 4.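

The entry for compound 4 in this assay is a limit and not a number: the limit of > 100000 nM in this assay, at which 1 of the 4 values shown sits.

An open chain on this amine nitrogen therefore does not by itself bring a low number: the chain of compound 4 holds an ethyl ester where the chain of compound 1 holds a second acetyl, and that one difference gives an at least 11-fold higher number from compound 1 to compound 4 (1.07 log units; beyond the scatter), a large step that the three earlier compounds gave no hint of. The ring-bearing groups also give lower numbers than this chain, as an at least 2.6-fold higher number from compound 2 to compound 4 (0.41 log units; beyond the scatter) and an at least 3.8-fold higher number from compound 3 to compound 4 (0.58 log units; beyond the scatter) show, so ring against open chain does not sort the series, with compound 1 and compound 4 as open chains at the two ends and compound 2 and compound 3 in the middle.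

The true size of these steps stays unknown, and nothing here says why the ethyl ester weighs so heavily on the number. As far as these compounds go, whether a methyl ester, a carboxylic acid or a primary amide in that place of the chain would read like compound 1 or like compound 4 also remains open.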